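This account rests on a few compounds, and the source may have more. Where it says the series, first, only, none or still open, it means among the compounds named here.

Of the compounds shown here, two have so far been tested in a functional assay on MDA-MB-231 cells (Homo sapiens) for inhibition, read by sulforhodamine B assay, tested at 10 uM; a higher number here means more inhibition at the concentration tested (going by the name of the read-out), a lower number less inhibition. Compound 1 `CN(C)c1ccc(C2CC(c3ccc(-n4ccnc4)cc3)=NN2)cc1` gives 7.6%, and compound 2 `CN1CCN(c2ccc(C3=NN(C(=O)CCCl)C(c4ccc(N(C)C)cc4)C3)cc2)CC1` gives 2.4%, which is the lower of the two numbers as read, though the gap to compound 1 lies within the scatter, so the two cannot be told apart. Compound 3 `CN1CCN(c2ccc(C3=NN(C(=O)c4ccc(F)cc4)C(c4ccc(N(C)C)cc4)C3)cc2)CC1` differs from compound 2 in one place: 4-fluorophenyl in place of 2-chloroethyl on a carbonyl carbon. Among the compounds with values here, no measured pair shows how such a change behaves here, so nothing beyond the scatter is expected from this one. For compound 3 the expected step is a number 3.6 percentage points higher from compound 2 to compound 3 (within the scatter), and its value in this assay is estimated at 6%, with a likely range from -10% to 25%.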

Compound 3, a percentage reported as inhibition, at one concentration (the size of the read-out at that concentration, not a potency): 3.5%
Estimate against measurement, compound 3: 2.5 percentage points above, and the stated range covers the measured number.
By their numbers in this assay, from the lowest: compounds 2, 3 and 1 (each within the scatter of the next).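

In this assay, putting 4-fluorophenyl in place of 2-chloroethyl on this carbonyl carbon gives a number 1.1 percentage points higher from compound 2 to compound 3 (within the scatter), so the two compounds cannot be told apart. This first measured pair at this position shows that adding an aromatic ring of carbon here produces no change that can be read beyond the scatter. Nothing available explains this result. Still open, going by these compounds, is whether an amine, a carboxylic acid or a longer chain on this carbonyl carbon would move the number beyond the scatter.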